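The compounds below may be only part of what the source reports. "The series", "measured", "known", "first", "only" and "open" are said of these compounds alone.

Measured so far:
Compound 1 `Cc1c(OCc2ccccc2)ccc2c(N3CCNCC3)cc(=O)oc12` with 1100 nM
Compound 2 `COc1c(C)cnc(COc2ccc3c(N4CCNCC4)cc(=O)oc3c2C)c1C` with 5800 nM

In a functional assay on a cell-free system (plasma, Homo sapiens) for inhibition, with Plasma (Rattus norvegicus) as the target (a higher number here means a weaker inhibitor, a lower number a stronger inhibitor), compound 2 stands at 5800 nM, the higher of the two numbers, which makes it the weaker inhibitor of the pair. Compound 3 `Cc1c(OCC2CCCN(C)C2)ccc2c(N3CCNCC3)cc(=O)oc12` differs from compound 2 by having 1-methylpiperidin-3-yl in place of 4-methoxy-3,5-dimethylpyridin-2-yl on a saturated chain carbon bound to an oxygen on an aromatic ring. Going by the values given here, only one measured step bears on this place, namely a 5.3-fold higher number from compound 1 to compound 2 (0.72 log units; beyond the scatter), where that same group replaced phenyl. Now the group leaves again, though for a non-aromatic ring with no measurement of its own. A modest move towards lower numbers in this assay is therefore expected, but one step cannot fix its size. The estimated change is a 2.3-fold lower number from compound 2 to compound 3 (0.37 log units; beyond the scatter), and it is only a rough figure. For compound 3 the expected value is 2500 nM, with an estimated range from 600 nM to 10000 nM.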

Compound 3, half-maximal inhibitory concentration: 16400 nM
The estimate for compound 3 lay 6.6-fold (0.82 log units) below the measured number, outside the stated range (above it).
By their numbers in this assay, from the lowest: compound 1; then compound 2; then compound 3.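

In this assay, replacing the aromatic 4-methoxy-3,5-dimethylpyridin-2-yl with the non-aromatic 1-methylpiperidin-3-yl did not bring the number back towards that of the phenyl compound, but gave a 2.8-fold higher number from compound 2 to compound 3 (0.45 log units; beyond the scatter). The comparison with phenyl itself shows a larger change, a 15-fold higher number from compound 1 to compound 3 (1.17 log units; beyond the scatter), so at this place both nitrogen-containing rings give weaker inhibition than phenyl, and the non-aromatic ring gives the weakest of the three. No measured evidence is available to explain this order.

The compounds shown do not separate the effect of the ring nitrogen from that of losing aromaticity, which a cyclohexyl group at the same place could test. An unsubstituted pyridin-2-yl group could likewise show how much the methoxy and methyl groups contribute to the number for compound 2.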